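The source may hold more compounds than are shown below. What is called first, only, known or untested is meant among the compounds shown, and "the series" means these compounds.

Compound 1 `Cc1cc(-c2ccc3[nH]c(=O)nc(-c4ccccc4)c3c2)ccn1` shares its core with compound 2 `O=c1nc(-c2ccccc2)c2cc(-c3cccc(F)c3)ccc2[nH]1` and compound 3 `O=c1nc(-c2ccccc2)c2cc(-c3cc[nH]n3)ccc2[nH]1`. In an ADME assay on L6 cells (Rattus norvegicus) for cytotoxicity, read by fluorescence and resazurin assay, with a stated time of 72 h (a lower number here means that less compound is needed, a higher number that more compound is needed for the effect), compound 1 gives only a limit, > 50000 nM, and no number. Compound 3 likewise sits at a limit in this assay, > 50000 nM. Compound 2 is the only one of the three with a number in this assay, 23000 nM. That gives the step of an at least 2.1-fold lower number from compound 1 to compound 2 (0.33 log units; beyond the scatter) and the step of an at least 2.1-fold higher number from compound 2 to compound 3 (0.33 log units; beyond the scatter), while the step that the two limits leave unreadable from compound 1 to compound 3 cannot be sized because the limit of > 50000 nM in this assay, at which 2 of the 3 values shown sit, holds both of its ends.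

Compound 4 `O=c1nc(-c2ccccc2)c2cc(N3CCNCC3)ccc2[nH]1` is not yet measured. It differs from compound 1 by piperazin-1-yl in place of 2-methylpyridin-4-yl on an aromatic carbon. Among the compounds with values here, no measured step carries this change; the two steps that start at compound 1, an at least 2.1-fold lower number from compound 1 to compound 2 (0.33 log units; beyond the scatter) and a step that the two limits leave unreadable from compound 1 to compound 3, show that one aryl replacement lowered the number modestly and another left it at the limit. For compound 4 a step no larger than the scatter is expected, a step that the limit leaves unreadable from compound 1 to compound 4, so that compound 4 is estimated to give 60000 nM in this assay, within a range from 20000 nM to 150000 nM.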

Compound 4, half-maximal effective concentration: > 25000 nM
Compound 4: a limit, no number; the forecaster's own chance of this, stated with the estimate: 60%; the middle value does not contradict the limit.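

In this assay compound 4, the first shown with a non-aromatic ring at this aromatic carbon, gives > 25000 nM, which is a limit and not a number. Piperazin-1-yl in place of 3-fluorophenyl gives an at least 1.0-fold higher number from compound 2 to compound 4 (0.03 log units; that floor lies within the scatter), so a non-aromatic ring here is not shown to differ from the only compound with a number, compound 2. The steps from compound 1 and compound 3 to compound 4 cannot be read, because limits hold both of their ends: the limit of > 25000 nM in this assay, at which 1 of the 4 values shown sits.

Going by these compounds, what stays open is where the value of compound 4 truly lies, and so whether piperazin-1-yl differs from 3-fluorophenyl at all. Also open, on these data alone, is what an open-chain amine such as dimethylamino, or a carboxylic acid, would give on this same carbon.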